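Extending the alkyl chain on a shared hydroxylated side chain

The source may report more compounds than this note shows. Statements on the series, on what has been measured and on what is new or still open speak of the compounds shown alone.

Three compounds were measured in a functional assay on L1210 cells (Mus musculus) for cytotoxicity; on this read-out higher numbers stand for an effect only at larger amounts of compound and lower numbers for an effect already at smaller amounts:
compound 1, `CCCCCC(O)C1=CC(=O)c2c(OC)ccc(OC)c2C1=O`: 0.378 ug/mL
compound 2, `CCC(O)c1cc(OC)c2c(c1OC)C(=O)C=CC2=O`: 0.085 ug/mL
compound 3, `COc1ccc(OC)c2c1C(=O)C=C(CO)C2=O`: 0.524 ug/mL

Compound 3 shows the largest of the three numbers. Its closest companion is compound 1, and the step of a 1.4-fold higher number from compound 1 to compound 3 (0.14 log units; within the scatter) is small enough to sit within the scatter, so the two cannot be told apart with confidence. Going by the values given here, compound 2, which gives 0.085 ug/mL, lies further off, and the gap between compound 3 and compound 2 exceeds the scatter; no single-point step connects those two, so only their values can be compared.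

Compound 4, `CCCCCCCC(O)C1=CC(=O)c2c(OC)ccc(OC)c2C1=O`, is the next member of this series. The change from compound 3 is heptyl in place of hydrogen on a saturated chain carbon bound to a double-bonded ring carbon and an oxygen on a saturated carbon. Among the compounds with values here, the only measured step that bears on it is the one from compound 1 to compound 3, where pentyl at the same place gave way to hydrogen, and that step stayed within the scatter. Heptyl reaches two carbons further than pentyl, and no measured pair covers that extension. The step of a 1.6-fold lower number from compound 3 to compound 4 (0.21 log units; within the scatter) is therefore expected to be modest, if anything a slightly lower number, as compound 1 with its pentyl chain gave 0.378 ug/mL. Compound 4 is estimated at 0.32 ug/mL, within a range from 0.1 ug/mL to 1 ug/mL.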

Compound 4, concentration for half-maximal effect: 1.04 ug/mL
Beside the measured number, compound 4's estimate is 3.3-fold (0.51 log units) below it, and the stated range ends below it.
By their numbers in this assay, from the lowest: compound 2; then compounds 1, 3 and 4 (each within the scatter of the next, the first and the last beyond it).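

In this assay, heptyl in place of hydrogen on the saturated chain carbon bound to a double-bonded ring carbon and an oxygen on a saturated carbon gives a 2.0-fold higher number from compound 3 to compound 4 (0.30 log units; within the scatter) and so stays within the scatter, as pentyl did at the same place. Going by these compounds alone, the new information lies in the comparison of the two chains: ethyl in place of hydrogen on a saturated chain carbon, six bonds along the chain from that ring carbon and oxygen, gives a 2.8-fold higher number from compound 1 to compound 4 (0.44 log units; beyond the scatter) and is the first step in this part of the series to pass the scatter, though only modestly, with compound 4 needing larger amounts of compound than compound 1 for the same effect. Neither chain can be told apart from hydrogen at this place, yet the heptyl and pentyl chains can be told apart from each other. Nothing measured here explains this result.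

The compounds shown leave open whether a longer chain than heptyl would carry the number further in the same direction, or whether a branched chain would behave like these straight ones. They also leave open what an amine or a carboxylic acid at the end of the chain would do at this place.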